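The compounds below may be only part of what the source reports. "The series", "measured", "known", "first", "only" and "open" are said of these compounds alone.

Compound 1 `NS(=O)(=O)c1ccc(C(=O)NNC(=O)c2ccccc2)cc1`: in an assay on cells for inhibition of Amine oxidase [flavin-containing] B (Homo sapiens), read by fluorescence and spectrophotometry, using microsomes, with a stated time of 20 min (a higher number here means a weaker inhibitor, a lower number a stronger inhibitor), compound 1 gives only a limit, > 100000 nM.
Compound 2 `NS(=O)(=O)c1ccc(C(=O)NNC(=O)c2ccc(Cl)cc2)cc1`: in this assay compound 2 gives 11700 nM.

Among the measured compounds shown here, compound 2 thus holds the only real number in this assay, the other value shown being a limit (the limit of > 100000 nM in this assay, at which 1 of the 2 values shown sits). Compound 3 `N#Cc1ccc(C(=O)NNC(=O)c2ccc(S(N)(=O)=O)cc2)cc1` differs from compound 2 in one place: cyano in place of chloro on an aromatic carbon. For the measured compounds named here, the single measured step, an at least 8.5-fold lower number from compound 1 to compound 2 (0.93 log units; beyond the scatter), concerns a different change and does not speak to cyano in place of chloro, so no measured step bears directly on this swap. A step within the scatter is expected, a 1.7-fold higher number from compound 2 to compound 3 (0.23 log units; within the scatter). Compound 3 is therefore expected to give about 20000 nM, between 6000 nM and 80000 nM.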

Compound 3, half-maximal inhibitory concentration: 1170 nM
Compound 3: middle estimate off by 17-fold (1.23 log units), on the high side; measured number outside the range, below it.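

The position does not merely reward replacing hydrogen: the identity of the group matters, since cyano in place of chloro gives a 10-fold lower number from compound 2 to compound 3 (1.00 log units; beyond the scatter) in this assay. Cyano in place of hydrogen gives an at least 85-fold lower number from compound 1 to compound 3 (1.93 log units; beyond the scatter), the largest step shown at this position. The size of that step is open-ended, since compound 1 gives a limit and not a number: the limit of > 100000 nM in this assay, at which 1 of the 3 values shown sits.

On these data alone, whether an amine, a carboxylic acid or a methoxy group in this place would track with chloro or with cyano stays open. So does whether the gain from cyano holds with any change elsewhere on the core of compound 3.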